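Replacing the pyridine headgroup with a propylphenyl ring

This account rests on a few compounds, and the source may have more. Where it says the series, first, only, none or still open, it means among the compounds named here.

Measured so far:
compound 1 `CN(C)C(=O)c1cccnc1NCCCN1CCN(c2ccccc2OCC(F)(F)F)CC1`, 0.1 nM
compound 2 `CN(C)C(=O)c1cccnc1NCCCN1CCN(c2ccccc2OCC2CC2)CC1`, 0.159 nM
compound 3 `Cc1cnccc1N1CCN(CCCNc2ncccc2C(=O)N(C)C)CC1`, 200 nM

In a functional assay for antagonist activity at Alpha-1A adrenergic receptor (Oryctolagus cuniculus) (a lower number here means tighter binding, a higher number weaker binding), compound 3 gives 200 nM, the highest number of the three, and it stands far apart from the other two: compound 1 gives 0.1 nM and compound 2 gives 0.159 nM, both gaps lying beyond the scatter. Compounds 1 and 2 share the same core and differ only at the group on the oxygen; the step of a 1.6-fold higher number from compound 1 to compound 2 (0.20 log units; within the scatter) lies within the scatter, so the two cannot be ordered.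

Compound 4 `CCCc1ccccc1N1CCN(CCCNc2ncccc2C(=O)N(C)C)CC1` differs from compound 3 in one place: 2-propylphenyl in place of 3-methylpyridin-4-yl on an amine nitrogen in a ring. For the measured compounds named here, no measured step follows this exact change. The step from compound 1 to compound 2 concerns a different part of the molecule and bears only loosely on it. What the values show is that compounds 1 and 2, which carry a substituted phenyl ring on the amine nitrogen in the ring, give far lower numbers than compound 3, which carries a pyridinyl ring there. Compound 4 also carries a substituted phenyl ring on that nitrogen, so a large step toward lower numbers is expected, a 200-fold lower number from compound 3 to compound 4 (2.30 log units; beyond the scatter). The estimate for compound 4 in this assay is 1 nM, with a range from 0.1 nM to 10 nM.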

Compound 4, dissociation constant: 0.2 nM
The estimate for compound 4 lay 5.0-fold (0.70 log units) above the measured number; low and high end bracket the measured number.
By their numbers in this assay, from the lowest: compounds 1, 2 and 4 (each within the scatter of the next); then compound 3.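

In this assay, the change to 2-propylphenyl from 3-methylpyridin-4-yl on the amine nitrogen in the ring is a 1000-fold lower number from compound 3 to compound 4 (3.00 log units; beyond the scatter), which gives this position its first measured one-place step. The other two steps show that the group on the aromatic carbon need not be attached through oxygen: propyl in place of cyclopropylmethoxy gives a 1.3-fold higher number from compound 2 to compound 4 (0.10 log units; within the scatter), and propyl in place of 2,2,2-trifluoroethoxy gives a 2.0-fold higher number from compound 1 to compound 4 (0.30 log units; within the scatter), both within the scatter, so compounds 1, 2 and 4 cannot be ordered. Nothing available here accounts for the large step or for the lack of separation among these three compounds.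

The step from compound 3 to compound 4 alters both the ring and its substituent, so the compounds shown do not separate the loss of the ring nitrogen from the arrival of the propyl chain; a pyridinyl ring bearing propyl, or an unsubstituted phenyl ring, would address that. Also open is whether the aromatic carbon tolerates an amine or a carboxylic acid as it does the three groups shown.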